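The source may hold more compounds than are shown below. What is called first, only, known or untested is meant among the compounds shown, and "the series" means these compounds.

In an ADME assay on Vero cells (Chlorocebus sabaeus) for cytotoxicity, read by MTT assay, with a stated time of 72 h (a higher number here means that more compound is tolerated, a lower number that less compound is tolerated), compound 1 `C[C@]1(CN2CCc3nc(N4CCC(F)(F)CC4)ccc3C2)Cn2cc([N+](=O)[O-])nc2O1` has the entry "not determined" (no result reported), so it offers no number for comparison. Compound 2 `C[C@]1(CN2CCc3nc(-c4cccc(Cl)c4F)ccc3C2)Cn2cc([N+](=O)[O-])nc2O1` gives > 32 ug/mL, which is a limit of the assay and not a number. Compound 3 `C[C@]1(CN2CCc3nc(-c4cc(Cl)ccc4F)ccc3C2)Cn2cc([N+](=O)[O-])nc2O1` gives > 32 ug/mL, which is likewise only a limit. Compound 3 therefore has no exact position on the scale, and the same holds for the other compounds shown. For the measured compounds named here, the one measured change of the substituted phenyl group, 5-chloro-2-fluorophenyl in place of 3-chloro-2-fluorophenyl, is a step that the two limits leave unreadable from compound 2 to compound 3. The evidence on tolerance in this assay is thus (the limit of > 32 ug/mL in this assay, at which 2 of the 3 values shown sit).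

Compound 4 `C[C@]1(CN2CCc3nc(-c4cc(F)cc(Cl)c4)ccc3C2)Cn2cc([N+](=O)[O-])nc2O1` keeps the same atoms as compound 3 but joins them differently: 3-chloro-5-fluorophenyl in place of 5-chloro-2-fluorophenyl on an aromatic carbon. Here 3-chloro-5-fluorophenyl replaces 5-chloro-2-fluorophenyl on the aromatic carbon next to the ring nitrogen. Going by the values given here, the only comparable change gave no readable size, so it supports no direction, and a step beyond the scatter is not expected. The estimated change, a step that the limit leaves unreadable from compound 3 to compound 4, is accordingly small, and another limit is the likeliest report. For compound 4 the expected value is 40 ug/mL. The estimated range for compound 4 runs from 20 ug/mL to 80 ug/mL.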

Compound 4, half-maximal cytotoxic concentration: > 32 ug/mL
Compound 4 ended at the assay's limit; the forecaster's own chance of this, stated with the estimate: 80%; the middle value is on the limit's open side.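

In this assay compound 4 gives > 32 ug/mL, which is a limit of the assay and not a number. No new step can be read: the steps from compound 2 and from compound 3 to compound 4 all join limits. The compounds shown leave open whether the 3-chloro-2-fluorophenyl, 5-chloro-2-fluorophenyl and 3-chloro-5-fluorophenyl groups differ at all in this assay.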